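The compounds below may be only part of what the source reports. "The series", "measured", "known", "first", "only" and "open" are said of these compounds alone.

In a functional assay on the whole organism (Hindlimb, strain albino) with Mus musculus as the target, in the maximal electroshock model, with a stated time of 0.5 h (on this read-out higher numbers stand for an effect only at larger amounts of compound and lower numbers for an effect already at smaller amounts), three compounds have been measured so far. Compound 1 `CC(=O)N1N=C(Nc2nc3ccc([N+](=O)[O-])cc3s2)CC1c1ccc(O)cc1` gives 162 umol/kg in this assay. Compound 2 `O=C(/C=C/c1ccccc1)Nc1nc2ccc([N+](=O)[O-])cc2s1` gives 485 umol/kg, and compound 3 `O=C(/C=C/c1ccccc1)Nc1nc2ccc(Cl)cc2s1` gives 425 umol/kg. Compound 1 carries the lowest of the three numbers, and its gap to each of the other two lies beyond the scatter, with compound 3 the nearer of the two.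

Compounds 2 and 3 differ in a single place: chloro in place of nitro on an aromatic carbon. The step this change made is a 1.1-fold lower number from compound 2 to compound 3 (0.06 log units; within the scatter), so the two compounds cannot be told apart on this read-out.

Compound 4 `CC(=O)N1N=C(Nc2nc3ccc(Cl)cc3s2)CC1c1ccc(O)cc1` has not yet been measured. It stands to compound 1 as compound 3 stands to compound 2: chloro in place of nitro on an aromatic carbon. The description of the place is the same word for word in both cases, so this is the same change, now made on the core of compound 1. How the core of compound 1 differs from the core of compound 2 is not broken down here.

The expectation for compound 4 rests on compounds 2 and 3, whose measured step a 1.1-fold lower number from compound 2 to compound 3 (0.06 log units; within the scatter) stayed within the scatter. A step of similar, small size is therefore expected for the change at hand, a 1.1-fold lower number from compound 1 to compound 4 (0.03 log units; within the scatter). Compound 4 is thus estimated at 150 umol/kg in this assay, within a likely range from 75 umol/kg to 300 umol/kg.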

Compound 4, dose for half-maximal effect: 106 umol/kg
Compound 4: the middle estimate sits 1.4-fold (0.15 log units) above what was measured; low and high end bracket the measured number.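

In this assay, putting chloro in place of nitro on the core of compound 1 gives a 1.5-fold lower number from compound 1 to compound 4 (0.18 log units; within the scatter), a step small enough to be ordinary scatter between repeated measurements. Set beside the same change on the other core, this step tells the same story, and the two steps cannot be told apart: the same change on two cores in this assay, a 1.1-fold lower number (0.06 log units; within the scatter) from compound 2 to compound 3 and a 1.5-fold lower number (0.18 log units; within the scatter) from compound 1 to compound 4, 1.3-fold (0.13 log units) apart, within the scatter of two such steps. This shows that, on the two cores here, the exchange of nitro for chloro on an aromatic carbon leaves the read-out where it was, so the near-absence of an effect carried over from one core to the other; it does not show that the same would hold on a third core, it gives no reason for the result, and it cannot show whether a large step would carry over as well, as both steps here are small.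

The compounds shown hold only nitro and chloro at this place, so it remains open whether an amine, a methoxy group or a carboxylic acid there would also leave the number within the scatter. Also open, as far as these compounds go, is whether a fluoro or bromo group would fit the same picture on both cores.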